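From pyrrolidin-1-yl to azepan-1-yl on a shared core

A few compounds are considered here, and "the series" means these few. Any claim that something is new, unique, unknown or untested is made for them only; others in the source may bear on it.

compound 1 `CCN(C)c1nc(Cc2c(F)cccc2F)cc(=O)[nH]1`: > 89000 nM (a limit)
compound 2 `CCN(CC)c1nc(Cc2c(F)cccc2F)cc(=O)[nH]1`: > 85000 nM (a limit)
compound 3 `O=c1cc(Cc2c(F)cccc2F)nc(N2CCCC2)[nH]1`: > 86000 nM (a limit)

In an ADME assay on MT4 cells (Homo sapiens) for cytotoxicity, read by MTT assay, with a stated time of 4 days (a lower number here means that less compound is tolerated, a higher number that more compound is tolerated), compound 3 stands at > 86000 nM, which is a limit and not a number. The other two compounds also give only limits, so the three cannot be ranked.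

Compound 4 `O=c1cc(Cc2c(F)cccc2F)nc(N2CCCCCC2)[nH]1` keeps the shared core but carries azepan-1-yl in place of pyrrolidin-1-yl on an aromatic carbon, between two ring nitrogen atoms: azepan-1-yl in place of pyrrolidin-1-yl on an aromatic carbon.

The closest comparisons are the other swaps of the group on that aromatic carbon: a step that the two limits leave unreadable from compound 1 to compound 3 and a step that the two limits leave unreadable from compound 2 to compound 3. A third comparison, a small change to the chain of that group, is a step that the two limits leave unreadable from compound 1 to compound 2. None of these gives a size or a direction to carry over, so no step beyond the usual scatter is expected in this assay. The expected outcome is an at least 1.0-fold lower number from compound 3 to compound 4 (0.03 log units; that floor lies within the scatter). Another limit is the most likely report for this new compound, although a real number cannot be ruled out. Compound 4 is estimated at 80000 nM, with an expected range from 35000 nM to 110000 nM.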

Compound 4, half-maximal cytotoxic concentration: > 78000 nM
Compound 4: no number, only a limit (the forecaster's own chance of this, stated with the estimate: 75%); the middle value does not contradict the limit.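

In this assay, among these compounds, compound 4 gives only a limit, as compounds 1, 2 and 3 do, so no step from any of these to compound 4 can be read, in size or in direction. The compounds shown leave open how much of each compound the cells actually tolerate, and whether the group on that aromatic carbon changes this at all.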